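Methyl to tert-butyl on compound 1

A few compounds are considered here, and "the series" means these few. Any claim that something is new, unique, unknown or untested is made for them only; others in the source may bear on it.

Measured in a functional assay on HepG2 cells (Homo sapiens) for cytotoxicity, read by WST assay, with a stated time of 24 h; on this read-out lower numbers stand for higher toxicity in this test and higher numbers for lower toxicity in this test:
Compound 1 `Cc1cc(-c2ccc3cc(CO)ccc3c2)ccc1O`: > 32 ug/mL
Compound 2 `Cc1cc(-c2ccc3cc(C(=O)O)ccc3c2)ccc1O`: > 32 ug/mL
Compound 3 `O=C(O)c1ccc2cc(-c3ccc(O)cc3)ccc2c1`: > 32 ug/mL

Each of these entries is a limit and not a number. Compound 1 itself stands at the limit > 32 ug/mL. Compound 4 `CC(C)(C)c1cc(-c2ccc3cc(CO)ccc3c2)ccc1O` differs from it by tert-butyl in place of methyl on an aromatic carbon, on an aromatic carbon ortho to a hydroxy group. Loss of the same methyl appears in a step that the two limits leave unreadable from compound 2 to compound 3. Among the measured compounds shown here, the only other measured step is a step that the two limits leave unreadable from compound 1 to compound 2. Because of the limit of > 32 ug/mL in this assay, at which 3 of the 3 values shown sit, neither step offers a size to carry over, so no step beyond the scatter is expected in this assay, in either direction. The estimated step is a number no higher from compound 1 to compound 4 (the limit leaves the size open). For compound 4 the expected value is 32 ug/mL. The estimated range for that compound runs from 12 ug/mL to 64 ug/mL.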

Compound 4, concentration lethal to 50% of the cells: 7.5 ug/mL
For compound 4 the middle estimate is 4.3-fold (0.63 log units) above the measured one; the whole stated range lies above it.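

In this assay, tert-butyl in place of methyl on an aromatic carbon ortho to a hydroxy group gives an at least 4.2-fold lower number from compound 1 to compound 4 (0.63 log units; beyond the scatter). Among the compounds shown here, this is the first change with a readable size, and it shows that this position can bring the read-out off its limit. The earlier steps cannot be read: the limit of > 32 ug/mL in this assay, at which 3 of the 4 values shown sit.

Only methyl and tert-butyl are shown with a group at this place alongside hydrogen, so the reading for an ethyl or isopropyl group stays open. Also open, on these data alone, is whether tert-butyl gives a similar step with the carboxy group of compound 2 in place of hydroxymethyl.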